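Swapping the Sulfonyl Substituent on a Pancreatic-Cancer Cell Inhibitor

The compounds below may be only part of what the source reports. "The series", "measured", "known", "first", "only" and "open" are said of these compounds alone.

Measured so far:
Compound 1 `CCC(CC)S(=O)(=O)c1ccc(S(=O)(=O)N2CCC[C@@H](C(=O)N3CCC(F)(F)CC3)C2)cc1` gives 13 nM in a functional assay on MIA PaCa-2 cells (Homo sapiens) for inhibition, read by MTT assay, with a stated time of 7 days; on this read-out higher numbers stand for weaker inhibition and lower numbers for stronger inhibition.
Compound 2 `CCN(CC)S(=O)(=O)c1ccc(S(=O)(=O)N2CCC[C@@H](C(=O)NC3CCOCC3)C2)cc1` gives 3770 nM in this assay.
Compound 3 `CCN(CC)S(=O)(=O)c1ccc(S(=O)(=O)N2CCC[C@@H](C(=O)N[C@H]3CC[C@@H](OC)CC3)C2)cc1` gives 960 nM in this assay.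

Among these three, compound 1 stands lowest in this assay, with both other numbers beyond the scatter above it. Compound 4 `CCN(CC)S(=O)(=O)c1ccc(S(=O)(=O)N2CCC[C@@H](C(=O)N3CCC(F)(F)CC3)C2)cc1` keeps everything of compound 1 except one group: diethylamino in place of pentan-3-yl on a sulfonyl sulfur. For the measured compounds named here, only one step is available within the measured set, a 3.9-fold lower number from compound 2 to compound 3 (0.59 log units; beyond the scatter), and it concerns the amide-type nitrogen, not the sulfonyl sulfur, so it says nothing about this change. Going by the values given here, compounds 2 and 3 do carry the diethylamino group that enters in compound 4, and their numbers are far higher than that of compound 1, but each also differs from compound 1 at the amide, so no single measured step isolates the sulfonyl change. The expectation for compound 4 therefore rests on weak ground: it is estimated to stay closer to compound 1 than to compounds 2 and 3, with a modest rise in the number as a 3.1-fold higher number from compound 1 to compound 4 (0.49 log units; beyond the scatter). Compound 4 is expected to give about 40 nM, within a range from 8 nM to 250 nM.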

Compound 4, half-maximal inhibitory concentration: 16 nM
Beside the measured number, compound 4's estimate is 2.5-fold (0.40 log units) above it; measured number inside the range.
By their numbers in this assay, from the lowest: compounds 1 and 4 (each within the scatter of the next); then compound 3; then compound 2.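

In this assay the step of a 1.2-fold higher number from compound 1 to compound 4 (0.09 log units; within the scatter) lies within the scatter, so on a sulfonyl sulfur, with the 4,4-difluoropiperidin-1-yl amide in place, diethylamino and pentan-3-yl cannot be told apart, even though one carries a nitrogen where the other has only carbon. With diethylamino now held constant, the group on the carbonyl carbon can be read on its own: the step of a 60-fold lower number from compound 3 to compound 4 (1.78 log units; beyond the scatter) and the step of a 240-fold lower number from compound 2 to compound 4 (2.37 log units; beyond the scatter) are both large, so among these compounds the wide gap in this read-out goes with the amide group and not with the sulfonyl substituent. The data shown offer no measurement that could explain either result.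

On these data alone, whether the two sulfonyl groups stay interchangeable with the oxan-4-yl or 4-methoxycyclohexyl amides remains open, as does the outcome with a smaller dimethylamino group or a morpholin-4-yl ring on the same sulfur. Also open, as far as these compounds go, is how much of the large steps depends on the two fluorines, which a plain piperidin-1-yl amide would address.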